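The compounds below may be only part of what the source reports. "The series", "measured", "known", "first", "only" and "open" are said of these compounds alone.

Compound 1, with structure `O=C1Nc2ccccc2C1(c1c[nH]c2ccccc12)c1c[nH]c2ccccc12`, is the parent of this small set. In a functional assay on DU-145 cells (Homo sapiens) for cytotoxicity, read by MTT assay, with a stated time of 48 h (a lower number here means a stronger inhibitor, a higher number a weaker inhibitor), compound 1 gives 8700 nM. Compound 3, `O=C1Nc2ccc(F)cc2C1(c1c[nH]c2ccccc12)c1c[nH]c2ccccc12`, carries one change relative to compound 1, namely (fluoro in place of hydrogen on an aromatic carbon), and in this assay compound 3 gives 12800 nM. The step of a 1.5-fold higher number from compound 1 to compound 3 (0.17 log units; within the scatter) is therefore small and does not separate the two compounds with confidence. Compound 2, `O=C1Nc2ccccc2C1(c1c[nH]c2ccc(Br)cc12)c1c[nH]c2ccc(Br)cc12`, has a different core; how the core of compound 2 differs from the core of compound 1 is not broken down here. In this assay compound 2 gives 3600 nM, the lowest number of the three, and its steps to compound 1 and compound 3 lie beyond the scatter.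

Compound 4, `O=C1Nc2ccc(F)cc2C1(c1c[nH]c2ccc(Br)cc12)c1c[nH]c2ccc(Br)cc12`, has not yet been measured. It differs from compound 2 by fluoro in place of hydrogen on an aromatic carbon, the same change already seen from compound 1 to compound 3. Because the earlier step of a 1.5-fold higher number from compound 1 to compound 3 (0.17 log units; within the scatter) stayed within the scatter, the step from compound 2 to compound 4 is expected to be similar, a 1.3-fold higher number from compound 2 to compound 4 (0.12 log units; within the scatter). On that basis compound 4 is estimated at 4800 nM in this assay, with a plausible range from 2200 nM to 11000 nM.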

Compound 4, half-maximal inhibitory concentration: 16300 nM
Beside the measured number, compound 4's estimate is 3.4-fold (0.53 log units) below it; the measured number lies above the stated range.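

On the core of compound 2, fluoro in place of hydrogen on an aromatic carbon gives a 4.5-fold higher number from compound 2 to compound 4 (0.66 log units; beyond the scatter) in this assay, whereas the same change on the core of compound 1 stays within the scatter. Among these compounds, the change therefore does not carry over with the same size from one core to the other: the same change on two cores in this assay, a 1.5-fold higher number (0.17 log units; within the scatter) from compound 1 to compound 3 and a 4.5-fold higher number (0.66 log units; beyond the scatter) from compound 2 to compound 4, 3.1-fold (0.49 log units) apart, beyond the scatter of two such steps This rests on only two pairs of compounds, so it does not show which feature of the core of compound 2 lies behind the gap, nor how the change would behave on any further core.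

The compounds shown leave open whether another group on that aromatic carbon, such as chloro, a methoxy group or an amine, would follow the result seen with fluoro on either core. They also leave open whether the gap between the two cores would appear in other cell lines or at other exposure times.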